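Trimming the Aromatic Tail: Phenyl in Place of Fluoromethylphenyl

The source may hold more compounds than are shown below. What is called first, only, known or untested is meant among the compounds shown, and "the series" means these compounds.

Compound 1 `Cc1ccc(S(=O)(=O)N[C@@H](CC(=O)NC(C)(C)C)C(=O)NCCNC(=O)c2cc(C)ccc2F)cc1` was tested in an ADME assay on HepG2 cells (Homo sapiens) for cytotoxicity; a lower number here means that less compound is needed, a higher number that more compound is needed for the effect. In this assay compound 1 gives > 11000 nM, which is a limit of the assay and not a number. Compound 2 `Cc1ccc(S(=O)(=O)N[C@@H](CC(=O)NC(C)(C)C)C(=O)NCCNS(=O)(=O)c2ccccc2)cc1` shares the core of compound 1 but carries a different group on the amine nitrogen. In this assay compound 2 gives > 11000 nM, again a limit rather than a number. The step that the two limits leave unreadable from compound 1 to compound 2 therefore cannot be read, and the limit of > 11000 nM in this assay, at which 2 of the 2 values shown sit, shows that both values sit at this limit. Compound 3 `Cc1ccc(S(=O)(=O)N[C@@H](CC(=O)NC(C)(C)C)C(=O)NCCNC(=O)c2ccccc2)cc1` differs from compound 1 by phenyl in place of 2-fluoro-5-methylphenyl on a carbonyl carbon. Within the data shown here, no measured step bears directly on this change; the only neighbouring step is the unreadable one from compound 1 to compound 2. Compound 3 is therefore expected to remain at the limit as well, with an expected step that the limit leaves unreadable from compound 1 to compound 3. The estimate for compound 3 in this assay is 20000 nM, within 8000 nM to 60000 nM.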

Compound 3, half-maximal effective concentration: > 11000 nM
Compound 3 gave a limit, no number; the forecaster's own chance of this, stated with the estimate: 85%; the middle value does not contradict the limit.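

In this assay compound 3 gives > 11000 nM, a limit and not a number. Among these compounds, no step among compound 1, compound 2 and compound 3 can be read. The compounds shown leave open whether these changes shift the value at all, as every result is the same limit: the limit of > 11000 nM in this assay, at which 3 of the 3 values shown sit.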